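The source may report more compounds than this note shows. Statements on the series, on what has been measured and on what is new or still open speak of the compounds shown alone.

Compound 1 `CCCCCCCCCCCCC#Cc1cn([C@H]2CC[C@@H](CO)O2)c(=O)[nH]c1=O` and compound 2 `CCCCCCCCC#Cc1cn([C@H]2C[C@H](F)[C@@H](CO)O2)c(=O)[nH]c1=O` share one core and differ at two places. In an ADME assay on cells (Fibroblast, Homo sapiens) for cytotoxicity, read by MTT assay (on this read-out higher numbers stand for lower toxicity in this test and lower numbers for higher toxicity in this test), compound 1 reaches only the limit of the assay, > 100 ug/mL. In this assay compound 2 likewise reaches only the limit, > 100 ug/mL. What is known so far is the limit of > 100 ug/mL in this assay, at which 2 of the 2 values shown sit. Compound 3 `CCCCCCCCCCCC#Cc1cn([C@H]2C[C@H](F)[C@@H](CO)O2)c(=O)[nH]c1=O` carries propyl in place of hydrogen on a saturated chain carbon, eight bonds along the chain from a triple-bonded carbon. For the measured compounds named here, no measured step speaks to this change, so no shift beyond the scatter is expected in this assay, and compound 3 is expected to stay near the limit with a step that the limit leaves unreadable from compound 2 to compound 3. For compound 3 the estimate is 120 ug/mL, ranging from 50 ug/mL to 300 ug/mL.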

Compound 3, half-maximal cytotoxic concentration: > 100 ug/mL
Compound 3 ended at the assay's limit; the forecaster's own chance of this, stated with the estimate: 80%; the middle value lies beyond the limit too.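

No step can be read between compound 2 and compound 3 in this assay, as both end at its limit: the limit of > 100 ug/mL in this assay, at which 3 of the 3 values shown sit. The compounds shown leave open whether propyl in place of hydrogen changes the half-maximal cytotoxic concentration at all.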